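A few compounds are considered here, and "the series" means these few. Any claim that something is new, unique, unknown or untested is made for them only; others in the source may bear on it.

Of the compounds shown here, three that share a long unsaturated chain have been tested in an assay on microsomes from intestinal mucosa for inhibition of acyl-CoA:cholesterol acyltransferase (Oryctolagus cuniculus); on this read-out higher numbers stand for weaker inhibition and lower numbers for stronger inhibition. Compound 1 `CCCCCCCC/C=C\CCCCCCCCNC(=O)c1c(C)cccc1C` gives 9800 nM. Compound 2 `CCCCCCCC/C=C\CCCCCCCCNC(=O)Nc1c(C)cc(C)cc1C` gives 2900 nM, and compound 3 `CCCCCCCC/C=C\CCCCCCCCNC(=O)Nc1c(Cl)cccc1Cl` gives 400 nM, the lowest of the three numbers and so the strongest inhibitor of the set, since both a 7.3-fold lower number from compound 2 to compound 3 (0.86 log units; beyond the scatter) and a 25-fold lower number from compound 1 to compound 3 (1.39 log units; beyond the scatter) lie beyond the scatter. Compound 4 `CCCCCCCC/C=C\CCCCCCCCNC(=O)Nc1c(C)cccc1Cl` is the next to be measured. It differs from compound 3 by methyl in place of chloro on an aromatic carbon. Within the data shown here, two measured steps bear on this change: a 7.3-fold lower number from compound 2 to compound 3 (0.86 log units; beyond the scatter), where chloro replaced methyl on the ring, and a 25-fold lower number from compound 1 to compound 3 (1.39 log units; beyond the scatter), where the same swap came together with a change from amide to urea; in both the number fell. Compound 4 keeps one chloro and takes one methyl, so a modest rise in the number, part of the way back towards compound 2, is expected: a 2.5-fold higher number from compound 3 to compound 4 (0.40 log units; beyond the scatter). Compound 4 is therefore estimated at 1000 nM, within a range from 400 nM to 2500 nM.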

Compound 4, half-maximal inhibitory concentration: 180 nM
Compound 4: middle estimate off by 5.6-fold (0.74 log units), on the high side; measured number below the stated range.
By their numbers in this assay, from the lowest: compound 4; then compound 3; then compound 2; then compound 1.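

Putting methyl in place of one chloro does not weaken inhibition here, as it gives a 2.2-fold lower number from compound 3 to compound 4 (0.35 log units; beyond the scatter), so the mixed 2-chloro-6-methylphenyl ring does better than the 2,6-dichlorophenyl ring. The earlier compounds shown here suggested that chloro on the ring simply beats methyl, but compound 4 goes against that: with a 16-fold lower number from compound 2 to compound 4 (1.21 log units; beyond the scatter) and a 54-fold lower number from compound 1 to compound 4 (1.74 log units; beyond the scatter), it is now the strongest inhibitor of the set, with one group of each kind rather than two chloro groups or only methyl groups. Among these compounds, nothing measured so far explains why this swap lowers the number.

Going by these compounds, what bromo or methoxy at this place would give remains open. So does how a urea carrying 2,6-dimethylphenyl would compare, which would separate the change from amide to urea from the change on the ring.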